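The source may hold more compounds than are shown below. What is called first, only, known or untested is meant among the compounds shown, and "the series" means these compounds.

Measured so far in a functional assay on UACC-257 cells (Homo sapiens) for cytotoxicity, read by sulforhodamine B assay, with a stated time of 48 h; a higher number here means a weaker inhibitor of growth, a lower number a stronger inhibitor of growth:

Compound 1, `ClCc1ccccc1Cn1cnc2c(Cl)nc(Cl)nc21`, gives 3890 nM.
Compound 2, `ClCc1ccccc1Cn1cnc2c(Cl)ncnc21`, gives 26300 nM.
Compound 3, `ClCc1cccc(Cn2cnc3ncnc(Cl)c32)c1`, gives 5490 nM.

Compounds 1 and 2 share a core and differ by one group: chloro in place of hydrogen on an aromatic carbon. That change gave a 6.8-fold lower number from compound 2 to compound 1 (0.83 log units; beyond the scatter). Compound 3 has the same atoms as compound 2 joined differently; the difference between the two cores is not broken down here. In this assay compound 3 stands close to compound 1, and its number is higher than that of compound 2.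

Compound 4, `ClCc1cccc(Cn2cnc3nc(Cl)nc(Cl)c32)c1`, has not yet been measured in this assay . It differs from compound 3 in the same way that compound 1 differs from compound 2: chloro in place of hydrogen on an aromatic carbon. The place of the change is described in the same words for both pairs, so it counts as the same change, made twice among these compounds.

Because compound 2 to compound 1 gave a 6.8-fold lower number from compound 2 to compound 1 (0.83 log units; beyond the scatter), the step from compound 3 to compound 4 is expected to be of similar size, a 6.1-fold lower number from compound 3 to compound 4 (0.79 log units; beyond the scatter). Compound 4 is therefore estimated at 900 nM, likely between 400 nM and 2500 nM.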

Compound 4, concentration for total growth inhibition: 15100 nM
The estimate for compound 4 lay 17-fold (1.22 log units) below the measured number, and the stated range ends below it.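

In this assay, chloro in place of hydrogen on an aromatic carbon gave a 2.8-fold higher number from compound 3 to compound 4 (0.44 log units; beyond the scatter), so the change did not carry over from the core of compound 2 to the core of compound 3, and the two steps run in opposite directions: the same change on two cores in this assay, a 6.8-fold lower number (0.83 log units; beyond the scatter) from compound 2 to compound 1 and a 2.8-fold higher number (0.44 log units; beyond the scatter) from compound 3 to compound 4, 19-fold (1.27 log units) apart, beyond the scatter of two such steps

This shows that, among these compounds, the outcome of the change depends on the core that carries it, and that a step read on one core cannot be transferred to the other. It does not show what in the two cores sets the steps apart, since the cores are not broken down further, and with one pair on each core it says nothing about any other core or any other assay.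

The compounds shown carry only chloro or hydrogen at this place, so it remains open whether an amine or a methoxy group there would also part the two cores. Also open is whether the chloromethyl group takes any part in the split, since it is the same group in all of these compounds.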